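Fluoro to Trifluoromethyl on Two Differently Substituted Urea Aryl Rings

The compounds below may be only part of what the source reports. "The series", "measured", "known", "first", "only" and "open" are said of these compounds alone.

Compound 1 `C[C@H](NC(=O)Nc1cccc(F)c1F)c1ccccc1` and compound 2 `C[C@@H](NC(=O)Nc1cc(F)ccc1F)c1ccccc1` share the same atoms joined differently; the difference between the two cores is not broken down here. In an ADME assay on the whole organism with Oryza sativa as the target, tested at 1 uM (a higher number here means a weaker effect of the compound at the concentration tested, a lower number a stronger effect), compound 1 gives 100%, and compound 2 gives 100%, level with compound 1 at the digits shown, the two together the highest of the three numbers known. Compound 3 `C[C@H](NC(=O)Nc1cccc(C(F)(F)F)c1F)c1ccccc1` carries the change trifluoromethyl in place of fluoro on an aromatic carbon relative to compound 1, and in this assay compound 3 gives 98%; the step is a number 2 percentage points lower from compound 1 to compound 3 (within the scatter).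

Compound 4 `C[C@@H](NC(=O)Nc1cc(C(F)(F)F)ccc1F)c1ccccc1`, not yet measured, is the counterpart on the core of compound 2, with the change (trifluoromethyl in place of fluoro on an aromatic carbon). This is the same kind of change as from compound 1 to compound 3, but not the same: in compound 3 the entering group is ortho to a fluoro group, whereas in compound 4 it is para to a fluoro group, both being meta to a large group. In this assay compound 4 is expected to sit close to compound 2, an estimated step of a number 1 percentage points lower from compound 2 to compound 4 (within the scatter), resting on the near-flat step a number 2 percentage points lower from compound 1 to compound 3 (within the scatter). The estimate for compound 4 is 99%, between 92% and 100%.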

Compound 4, a percentage reported as activity, at one concentration (the size of the read-out at that concentration, not a potency): 70%
Compound 4: the middle estimate sits 29 percentage points above what was measured, outside the stated range (below it).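

In this assay, trifluoromethyl in place of fluoro, para to a fluoro group on the core of compound 2, gives a number 30 percentage points lower from compound 2 to compound 4 (beyond the scatter), and this does not match what the same kind of change did on the core of compound 1: the same change on two cores in this assay, a number 2 percentage points lower (within the scatter) from compound 1 to compound 3 and a number 30 percentage points lower (beyond the scatter) from compound 2 to compound 4, 28 percentage points apart, beyond the scatter of two such steps. The near-flat result on one core therefore did not carry over to the other, so in this series the effect of this change cannot be taken from one core to the next. With a single pair on each core, the data do not show whether the gap follows from where the trifluoromethyl enters or from some other difference between the two cores, and they say nothing about why the steps differ.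

The compounds shown leave open whether chloro, methyl or a nitrile at the same place on the core of compound 2 would give a step of similar size. They also leave open how an amine or a carboxylic acid there would read in this assay.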